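The source may hold more compounds than are shown below. What is called first, only, known or untested is meant among the compounds shown, and "the series" means these compounds.

Three compounds sharing one core have so far been measured in an ADME assay on PC-3 cells (Homo sapiens) for cytotoxicity, read by WST assay, tested at 100 uM; a lower number here means less inhibition, a higher number more inhibition at the concentration tested (going by the name of the read-out):

Compound 1, `C=Cc1cccc(C(=O)N2CCCC(C(=O)Nc3ccc(Cl)cc3)C2)c1`: in this assay compound 1 gives 0%.
Compound 2, `O=C(Nc1ccc(Cl)cc1)C1CCCN(C(=O)c2cccc(-c3ccco3)c2)C1`: in this assay compound 2 gives 0%.
Compound 3, `Cc1cccc(C(=O)N2CCCC(C(=O)Nc3ccc(Cl)cc3)C2)c1`: in this assay compound 3 gives 0%.

Compound 3 stands level with both of its companions. The step of no change at the digits printed from compound 1 to compound 3 (within the scatter) and the step of no change at the digits printed from compound 2 to compound 3 (within the scatter) both lie within the scatter, as does the step of no change at the digits printed from compound 1 to compound 2 (within the scatter), so none of the three exchanges on an aromatic carbon, vinyl, furan-2-yl or methyl, moved the read-out at all.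

The next compound, compound 4, `CSc1cccc(C(=O)N2CCCC(C(=O)Nc3ccc(Cl)cc3)C2)c1`, differs from compound 3 by methylsulfanyl in place of methyl on an aromatic carbon. For the measured compounds named here, no measured step introduces methylsulfanyl, so the only guidance is indirect: every variation at that aromatic carbon among compounds 1, 2 and 3 left the read-out flat, and the series as a whole shows no response to the group carried there. On that basis compound 4 is expected to behave like compound 3, with the step of no change at the digits printed from compound 3 to compound 4 (within the scatter) expected to stay within the scatter. For compound 4 the estimated read-out is 0%, with a range from -10% to 15%.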

Compound 4, a percentage reported as inhibition, at one concentration (the size of the read-out at that concentration, not a potency): 0%
Beside the measured number, compound 4's estimate shows no gap at the digits printed; low and high end bracket the measured number.
By their numbers in this assay, from the lowest: compounds 1, 2, 3 and 4 (each within the scatter of the next).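

Exchanging methyl for methylsulfanyl gives no change at the digits printed from compound 3 to compound 4 (within the scatter) in this assay, so a group carrying a sulfur atom, the first at this aromatic carbon among these compounds, fits the flat picture as well. The comparisons with the other two groups agree, with no change at the digits printed from compound 2 to compound 4 (within the scatter) for methylsulfanyl in place of furan-2-yl and no change at the digits printed from compound 1 to compound 4 (within the scatter) for methylsulfanyl in place of vinyl, so the flat reading now spans four groups at this one place on the shared core. For the compounds shown here, with compound 4 also at 0% and no compound above that level, the series holds no inhibition that a group could have lowered, so these results can show only that none of the four raises it.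

On these data alone, whether an amine, a carboxylic acid or a longer chain at this aromatic carbon would lift the read-out remains open. So does whether an exchange elsewhere on the shared core, such as a different group in place of the chlorine, would change it. Nothing given here bears on why the read-out stays flat across these compounds.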